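The source may hold more compounds than are shown below. What is called first, only, known or untested is meant among the compounds shown, and "the series" means these compounds.

Working notes on the series. Among the measured compounds shown here, in a physicochemical assay for lipophilicity, read by LC-MS, in phosphate buffer, measured as octanol-water partition, with a stated time of 30 min, at pH 7.4, tested at 200 mM (a lower number here means a more polar compound, a higher number a more lipophilic compound), compound 3 `Cn1c(COc2cccc(C(=O)O)c2)nc2ccc(Oc3ccccn3)cc21` gives 0.4, the lowest of the three numbers measured so far. Compound 1 `Cc1ccc(Oc2ccc3nc(COc4cccc(C(=O)O)c4)n(C)c3n2)cc1F` gives 2.1 in this assay, and compound 2 `Cn1c(COc2cccc(C(=O)O)c2)nc2ccc(Oc3ccc4c(c3)CCC4)nc21` gives 2.5 in this assay; between those two stands a number 0.40 log units higher from compound 1 to compound 2 (beyond the scatter). Compound 3 lies beyond the scatter below both, with compound 1 the nearer and compound 2 the further neighbour.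

Compound 4 `Cn1c(COc2cccc(C(=O)O)c2)nc2ccc(Oc3cccc(Cl)n3)cc21` has not yet been measured. It differs from compound 3 by chloro in place of hydrogen on an aromatic carbon, placed on an aromatic carbon of a six-membered aromatic ring with one nitrogen, next to the ring nitrogen, so that pyridin-2-yl becomes 6-chloropyridin-2-yl. For the measured compounds named here, no measured step in this set covers a chloro entering on an aromatic carbon. Going by the values given here, the single measured step, from compound 1 to compound 2, exchanges one whole aryl group on the ring oxygen for another and is only a distant guide. For compound 4 the expected step is a number 0.60 log units higher from compound 3 to compound 4 (beyond the scatter) in this assay, upward. The estimate for compound 4 in this assay is 1, within a range from 0.5 to 1.5.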

Compound 4, distribution coefficient: 1.2
Estimate against measurement, compound 4: 0.20 log units below; measured number inside the range.
By their numbers in this assay, from the lowest: compound 3; then compound 4; then compound 1; then compound 2.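

Chloro in place of hydrogen on an aromatic carbon, next to the ring nitrogen of the six-membered aromatic ring with 1 nitrogen, gives a number 0.80 log units higher from compound 3 to compound 4 (beyond the scatter) in this assay. Among the compounds shown here, this is the first measured step at this position, and the first that changes a single atom on the aryl group on the ring oxygen rather than exchanging the whole group, so even one chlorine here moves the number beyond the scatter. Nothing measured alongside this result gives an account of the step.

Since a single step rests on one pair, it sets no pattern for the position. On these data alone, whether a methoxy or an amine at this same carbon would move the number in the same direction, and by how much, stays open.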